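The compounds below may be only part of what the source reports. "The series", "measured", "known", "first", "only" and "open" are said of these compounds alone.

In a functional assay on MGC-803 cells (Homo sapiens) for antiproliferative activity, read by MTT assay, with a stated time of 72 h (a higher number here means a weaker inhibitor, a lower number a stronger inhibitor), compound 1, whose structure is `Cc1ccc(-c2nc(CNc3ccc(C(=O)NO)cc3)n(-c3ccccc3)n2)cc1`, gives a value of > 20000 nM; that figure is a limit of the assay rather than a measured number. Compound 1 therefore stands at the weak end of the three measured compounds (the limit of > 20000 nM in this assay, at which 1 of the 3 values shown sits). The companions are compound 3 `Cc1ccsc1-c1nc(CNc2ccc(C(=O)NO)cc2)n(-c2ccccc2)n1`, which in this assay gives 8890 nM, and compound 2 `COc1ccc(-n2nc(-c3ccccc3)nc2CNc2ccc(C(=O)NO)cc2)cc1`, which in this assay gives 7050 nM.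

Compound 4 has the structure `O=C(NO)c1ccc(NCc2nc(-c3ccccc3)nn2-c2ccccc2)cc1`. It differs from compound 1 by hydrogen in place of methyl on an aromatic carbon, a change at the same aromatic carbon that is altered between compound 1 and compound 3.

For the measured compounds named here, only one measured step touches that position: an at least 2.2-fold lower number from compound 1 to compound 3 (0.35 log units; beyond the scatter). That step exchanges the whole aryl group, whereas the step to compound 4 removes only a methyl, so a smaller movement is expected, and because compound 1 sits at a limit of > 20000 nM in this assay, at which 1 of the 3 values shown sits, its true value may lie anywhere beyond it. Going by the values given here, compound 2 shows that a phenyl on the shared core is compatible with a measurable number, 7050 nM, though no step links it to compound 4.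

Compound 4 is therefore estimated at 15000 nM, within a range from 6000 nM to 40000 nM, a step of an at least 1.3-fold lower number from compound 1 to compound 4 (0.12 log units; that floor lies within the scatter) that is expected to be small or at the edge of the scatter.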

Compound 4, half-maximal inhibitory concentration: 17700 nM
Compound 4: middle estimate off by 1.2-fold (0.07 log units), on the low side; the range from low to high includes it.
By their numbers in this assay, from the lowest: compounds 2, 3 and 4 (each within the scatter of the next, the first and the last beyond it). At a limit, above all of these: compound 1.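

Phenyl in place of 4-methylphenyl brings this position onto a readable scale in this assay, but the change reads only as an at least 1.1-fold lower number from compound 1 to compound 4 (0.05 log units; that floor lies within the scatter), so removing the methyl cannot be said to lower the number. Compound 1 itself remains a limit of the assay: the limit of > 20000 nM in this assay, at which 1 of the 4 values shown sits.

The aryl exchange also looks different now, as a 2.0-fold higher number from compound 3 to compound 4 (0.30 log units; within the scatter) leaves phenyl and 3-methylthiophen-2-yl unseparated at this position, while a 2.5-fold higher number from compound 2 to compound 4 (0.40 log units; beyond the scatter) shows a modest difference when methoxy gives way to hydrogen on a different aromatic carbon from the one that carries the methyl of compound 1.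

Still open, on these data alone, is whether an amine, a carboxylic acid or a longer chain such as propyl in place of the methyl would move the number beyond the scatter relative to phenyl. Also open, as far as these compounds go, is how far the true value of compound 1 lies past its limit, and with it the real size of the change from 4-methylphenyl to phenyl.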